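Trimming an Ethyl to Methyl in a Weak Inhibitor Pair

The compounds below may be only part of what the source reports. "The series", "measured", "known", "first", "only" and "open" are said of these compounds alone.

Of the compounds shown here, two sharing one core have been tested in a functional assay on PC-3 cells (Homo sapiens) for inhibition, read by MTT assay, with a stated time of 48 h; a lower number here means a stronger inhibitor, a higher number a weaker inhibitor. Compound 1 `CCn1c(/C=C2\SC(=O)N(CC(=O)Nc3cc(C(C)(C)C)on3)C2=O)nc2ccccc21` is reported as > 50000 nM, which is a limit of the assay rather than a number. Compound 2 `CCn1c(/C=C2\SC(=O)N(CC(=O)N3CCc4cc(OC)c(OC)cc4C3)C2=O)nc2ccccc21`, which carries a different amide substituent on the same core, gives 33500 nM in this assay. Among the values shown, compound 2 therefore holds the only measured number; the other entry is a limit (the limit of > 50000 nM in this assay, at which 1 of the 2 values shown sits). Compound 3 `COc1cc2c(cc1OC)CN(C(=O)CN1C(=O)S/C(=C\c3nc4ccccc4n3C)C1=O)CC2` differs from compound 2 in one place: hydrogen in place of methyl on a saturated chain carbon bound to an aromatic nitrogen, that is ethyl to methyl, turning 1-ethyl-1H-benzimidazol-2-yl into 1-methyl-1H-benzimidazol-2-yl. Among the measured compounds shown here, no measured pair shows a step of this kind, so nothing sets its size; a change this small is expected to move the result by no more than the scatter, in no particular direction. The step from compound 2 to compound 3 is expected to read a 1.0-fold higher number from compound 2 to compound 3 (0.02 log units; within the scatter). Compound 3 is thus estimated at 35000 nM, with a range from 15000 nM to 80000 nM.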

Compound 3, half-maximal inhibitory concentration: 41100 nM
Compound 3: the middle estimate sits 1.2-fold (0.07 log units) below what was measured, within the range that was stated.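

Among the compounds shown here, the step gives the first reading at this position: in this assay, hydrogen in place of methyl on a saturated chain carbon bound to an aromatic nitrogen, that is ethyl to methyl, reads as a 1.2-fold higher number from compound 2 to compound 3 (0.09 log units; within the scatter). Compound 2 and compound 3 therefore cannot be told apart here, so on this core and with this amide substituent, the trim leaves the result within the scatter. Nothing shown bears on why the step has this size.

As far as these compounds go, whether a propyl chain, a benzyl group or a 2-hydroxyethyl chain in place of the ethyl would read differently stays open. From the compounds shown here alone, whether the same trim would read alike with the other amide substituent also stays open: compound 1 gives > 50000 nM, which is a limit.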